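The source may report more compounds than this note shows. Statements on the series, on what has been measured and on what is new or still open speak of the compounds shown alone.

In a functional assay on CHO cells for agonist activity at Melanocortin receptor 4 (Homo sapiens), read by cAMP accumulation (a higher number here means a larger maximal response, a lower number a smaller maximal response), the measured compounds are:
compound 1 `CC[C@H](NC(C)=O)c1cc(Cl)ccc1C1CCN(C(=O)[C@@H]2CN(C(C)(C)C)C[C@H]2c2ccc(F)cc2F)CC1`, which gives 108%
compound 2 `CC[C@H](NC(C)=O)c1cc(Cl)ccc1C1CCN(C(=O)[C@@H]2CN(C(C)(C)C)C[C@H]2c2ccc(F)cc2Cl)CC1`, which gives 84%

Compound 2 stands lowest of the two numbers; its nearest neighbour is compound 1, whose maximal response lies higher by a number 24 percentage points lower from compound 1 to compound 2 (beyond the scatter), a step beyond the usual scatter. Compound 3 `CC[C@H](NC(C)=O)c1cc(Cl)ccc1C1CCN(C(=O)[C@@H]2CN(C(C)(C)C)C[C@H]2c2ccc(Cl)cc2F)CC1` has the same atoms as compound 2, joined differently: 4-chloro-2-fluorophenyl in place of 2-chloro-4-fluorophenyl on a saturated ring carbon. Among the compounds with values here, the only measured step that bears on this change is a number 24 percentage points lower from compound 1 to compound 2 (beyond the scatter), a modest lowering on going from fluoro to chloro on an aromatic carbon. Within the data shown here, compound 3 is not a straight continuation of that step: the two halogens exchange their places rather than one replacing the other, and no measured pair covers such an exchange. A step of about a number 11 percentage points higher from compound 2 to compound 3 (beyond the scatter) in this assay is therefore expected, upward, but possibly within the scatter. For compound 3 the estimate is 95%, with a range from 72% to 115%.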

Compound 3, largest response reached (reported as percent of maximum), in percent of the reference or control that the assay uses: 97%
Compound 3: the middle estimate sits 2 percentage points below what was measured; measured number inside the range.
By their numbers in this assay, from the lowest: compound 2; then compound 3; then compound 1.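

In this assay the exchange of the two halogens is not neutral (a number 13 percentage points higher from compound 2 to compound 3 (beyond the scatter)), so at this saturated ring carbon the response depends on where each halogen sits on the phenyl ring, not only on which halogens are present. Chloro in place of fluoro also lowers the response when it produces the 4-chloro-2-fluorophenyl group (a number 11 percentage points lower from compound 1 to compound 3 (beyond the scatter)), so both chloro replacements shown give a lower number, the 2-chloro-4-fluorophenyl group by the larger step. Nothing available explains why the two placements differ.

From the compounds shown here alone, it remains open whether a 2,4-dichlorophenyl group, with chloro in both places, would lower the response further. The compounds also leave open how a methyl or methoxy group in either place would compare with these halogens.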